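A methyl added beside the ring nitrogen of compound 3

A few compounds are considered here, and "the series" means these few. Any claim that something is new, unique, unknown or untested is made for them only; others in the source may bear on it.

Compound 3 `Clc1cncc(N2CCNCC2)c1` carries a chloro group on a shared piperazine-bearing core. In a functional assay on HEK293 cells for agonist activity at Neuronal acetylcholine receptor; alpha4/beta2 (Homo sapiens), read by FLIPR and calcium flux (a higher number here means that more compound is needed for the effect, a lower number that less compound is needed), compound 3 gives 22900 nM, the highest of the three numbers measured; its nearest neighbour is compound 1 `C=COc1cncc(N2CCNCC2)c1`, which in this assay gives 7590 nM, and the furthest is compound 2 `Brc1ccc(N2CCCNCCC2)cn1`, which gives 1.29 nM. Among the measured compounds shown here, the only single-point step measured here is a 3.0-fold higher number from compound 1 to compound 3 (0.48 log units; beyond the scatter), a modest shift. Compound 4 `Cc1ncc(N2CCNCC2)cc1Cl` differs from compound 3 by methyl in place of hydrogen on an aromatic carbon. For the measured compounds named here, no measured step exchanges hydrogen for methyl, and compound 2 differs from the others in several places at once, so it says nothing direct about this change. Going by the values given here, with no comparable precedent, a small shift in either direction is the most that can be supported, and the one measured step, a 3.0-fold higher number from compound 1 to compound 3 (0.48 log units; beyond the scatter), shows how modest single-group changes have been on this core. Compound 4 is therefore expected to give 15000 nM, within a range of 4000 nM to 60000 nM, meaning an estimated step of a 1.5-fold lower number from compound 3 to compound 4 (0.18 log units; within the scatter).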

Compound 4, half-maximal effective concentration: 26900 nM
Compound 4: the middle estimate sits 1.8-fold (0.25 log units) below what was measured; low and high end bracket the measured number.
By their numbers in this assay, from the lowest: compound 2; then compound 1; then compounds 3 and 4 (each within the scatter of the next).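

In this assay, among the compounds shown here, methyl in place of hydrogen on an aromatic carbon, next to the ring nitrogen and ortho to a chloro group, gives a 1.2-fold higher number from compound 3 to compound 4 (0.07 log units; within the scatter) and is the first measured exchange of this kind on the shared core. Compound 3 and compound 4 therefore read alike, so at this position the added methyl produces no change that can be told from the usual scatter of the assay. No measured evidence bears on this result.

Going by these compounds, whether an ethyl chain, an amine or a carboxylic acid at the same position would also leave the number in place remains open. On these data alone, it is also open whether the same methyl would read alike with vinyloxy in place of the chloro group, as on the core of compound 1.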